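A Nitrophenyl in Place of Dichlorophenyl: What to Expect

The compounds below may be only part of what the source reports. "The series", "measured", "known", "first", "only" and "open" are said of these compounds alone.

Measured so far in a functional assay on NB-4 cells (Homo sapiens) for inhibition, read by XTT assay, with a stated time of 48 h; on this read-out lower numbers stand for stronger inhibition and higher numbers for weaker inhibition:
Compound 1, `COc1ccc(C(=O)/C(=C/C2CCCCC2)CCOC(C)=O)cc1`, reaches only a limit of the assay, > 100000 nM.
Compound 2, `C=C(C(=O)c1ccc(OC)cc1)C(OC(C)=O)c1ccc(Cl)cc1Cl`, gives 5400 nM.
Compound 3, `C=C(C(=O)c1ccc(OC)cc1)C(OC(=O)c1ccccc1)c1ccc(Cl)cc1Cl`, gives 9700 nM.

Compound 3 carries the highest of the two numbers, yet the step of a 1.8-fold higher number from compound 2 to compound 3 (0.25 log units; within the scatter) leaves it within the scatter of compound 2, so the two cannot be ranked. Compound 1 stands at the limit of > 100000 nM in this assay, at which 1 of the 3 values shown sits, and offers no number to compare.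

Compound 4, `C=C(C(=O)c1ccc(OC)cc1)C(OC(=O)c1ccccc1)c1ccccc1[N+](=O)[O-]`, differs from compound 3 in one place: 2-nitrophenyl in place of 2,4-dichlorophenyl on a saturated chain carbon bound to a double-bonded chain carbon and an oxygen next to a carbonyl group. For the measured compounds named here, no measured step touches this position. Going by the values given here, the only measured step, a 1.8-fold higher number from compound 2 to compound 3 (0.25 log units; within the scatter), concerns the ester end of the molecule and stayed within the scatter, so it gives no direct guide. With one aryl group exchanged for another and nothing measured to point either way, no step beyond the scatter is expected in this assay, with the range kept wide. Compound 4 is therefore estimated at 15000 nM, between 4000 nM and 60000 nM. The expected step is a 1.5-fold higher number from compound 3 to compound 4 (0.19 log units; within the scatter).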

Compound 4, half-maximal inhibitory concentration: 12700 nM
Compound 4: middle estimate off by 1.2-fold (0.07 log units), on the high side; the range from low to high includes it.
By their numbers in this assay, from the lowest: compounds 2, 3 and 4 (each within the scatter of the next, the first and the last beyond it). At a limit, above all of these: compound 1.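

On the saturated chain carbon bound to a double-bonded chain carbon and an oxygen next to a carbonyl group, 2-nitrophenyl in place of 2,4-dichlorophenyl gives a 1.3-fold higher number from compound 3 to compound 4 (0.12 log units; within the scatter) in this assay. For the compounds shown here, this is the first measured change at this position, and it shows that two aryl groups with different atoms, one with hydrogen-bond acceptors and one without, cannot be told apart on this read-out. Nothing shown here bears on why the two read alike.

From the compounds shown here alone, whether a plain phenyl, or a phenyl carrying an amine or a carboxylic acid, on this carbon would move the number beyond the scatter of compound 3 stays open. Also open, going by these compounds, is whether the same aryl exchange would read alike with methyl in place of phenyl on the ester carbonyl carbon.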